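The compounds below may be only part of what the source reports. "The series", "measured", "known", "first", "only" and "open" are said of these compounds alone.

Three analogues on the shared core have been measured. Compound 1 `S=C(Nc1ccccc1)N1N=C(c2ccccc2)CC1c1ccc2c(c1)OCCO2` gives 57600 nM in a functional assay on HCT-116 cells (Homo sapiens) for antiproliferative activity, read by MTT assay, with a stated time of 48 h; on this read-out lower numbers stand for stronger inhibition of growth and higher numbers for weaker inhibition of growth; compound 2 `S=C(Nc1ccccc1)N1N=C(c2ccc(Br)cc2)CC1c1ccc2c(c1)OCCO2` gives 32100 nM, a step of a 1.8-fold lower number from compound 1 to compound 2 (0.25 log units; within the scatter); compound 3 `FC(F)(F)c1ccc(C2=NN(C(=S)Nc3ccccc3)C(c3ccc4c(c3)OCCO4)C2)cc1` gives 112000 nM, the highest of the three numbers, though a 1.9-fold higher number from compound 1 to compound 3 (0.29 log units; within the scatter) keeps it within the scatter of compound 1, while a 3.5-fold higher number from compound 2 to compound 3 (0.54 log units; beyond the scatter) lies beyond it. Compound 4 `CSc1ccc(C2=NN(C(=S)Nc3ccccc3)C(c3ccc4c(c3)OCCO4)C2)cc1` carries the change (methylsulfanyl in place of trifluoromethyl on an aromatic carbon). Among the measured compounds shown here, no measured step introduces methylsulfanyl; the steps that bear on it are the ones that placed trifluoromethyl, of modest or smaller size. A return towards the numbers of compound 1 and compound 2 is therefore expected, with a 2.2-fold lower number from compound 3 to compound 4 (0.35 log units; beyond the scatter) in the lowering direction. Compound 4 is estimated at 50000 nM, within 18000 nM to 140000 nM.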

Compound 4, concentration for 50% growth inhibition: 193000 nM
Compound 4: middle estimate off by 3.9-fold (0.59 log units), on the low side, and the stated range ends below it.
By their numbers in this assay, from the lowest: compounds 2, 1, 3 and 4 (each within the scatter of the next, the first and the last beyond it).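

At this position in this assay, methylsulfanyl stays close to trifluoromethyl, with a 1.7-fold higher number from compound 3 to compound 4 (0.24 log units; within the scatter) and no return towards the other two compounds. Among the compounds shown here, it is the first group here whose step from hydrogen passes the scatter, with a 3.4-fold higher number from compound 1 to compound 4 (0.53 log units; beyond the scatter) as the printed size. Against bromo the gap widens, with a 6.0-fold higher number from compound 2 to compound 4 (0.78 log units; beyond the scatter) on the same side. No evidence on this result is available.

On these data alone, whether an amine or a carboxylic acid at this position would give a number lower than that of compound 2 remains open.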